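A Second Chloro Group and Tolerance in Kidney Cells

A few compounds are considered here, and "the series" means these few. Any claim that something is new, unique, unknown or untested is made for them only; others in the source may bear on it.

Of the compounds shown here, three have been measured in a functional assay on TK-10 cells (Homo sapiens) for cytotoxicity, read by sulforhodamine B assay, with a stated time of 48 h; a higher number here means that more compound is tolerated, a lower number that less compound is tolerated. Compound 1 `ClCc1cccc(Cn2cnc3c(Cl)ncnc32)c1` gives 46800 nM in this assay. Compound 2 `ClCc1cccc(Cn2cnc3c(Cl)nc(Cl)nc32)c1` differs from compound 1 by a single change, (chloro in place of hydrogen on an aromatic carbon), and in this assay compound 2 gives 8910 nM; the resulting step is a 5.3-fold lower number from compound 1 to compound 2 (0.72 log units; beyond the scatter).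

Compound 3 `ClCc1ccccc1Cn1cnc2ncnc(Cl)c21` is built from the same atoms as compound 1, joined differently; the difference between the two cores is not broken down here. In this assay compound 3 gives 33900 nM, which lies within the usual scatter of the value of compound 1, and beyond it relative to compound 2.

Compound 4 `ClCc1ccccc1Cn1cnc2nc(Cl)nc(Cl)c21` has not yet been measured. It differs from compound 3 by chloro in place of hydrogen on an aromatic carbon, and the surroundings of the place are the same in both pairs, so this is the same change that carried compound 1 to compound 2. That change has been seen only once among these compounds, and the two cores on which it is made are not compared in detail, so the expectation rests on a single example. Because the first instance gave a 5.3-fold lower number from compound 1 to compound 2 (0.72 log units; beyond the scatter), a step of similar size is expected from compound 3 to compound 4, namely a 4.5-fold lower number from compound 3 to compound 4 (0.66 log units; beyond the scatter). Compound 4 is therefore estimated to give 7500 nM in this assay, with a plausible range from 3000 nM to 20000 nM.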

Compound 4, concentration lethal to 50% of the cells: 60300 nM
For compound 4 the middle estimate is 8.0-fold (0.91 log units) below the measured one; the whole stated range lies below it.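

In this assay, chloro in place of hydrogen on an aromatic carbon gives a 1.8-fold higher number from compound 3 to compound 4 (0.25 log units; within the scatter), so the clear drop seen on the first core does not carry over to the second: the same change on two cores in this assay, a 5.3-fold lower number (0.72 log units; beyond the scatter) from compound 1 to compound 2 and a 1.8-fold higher number (0.25 log units; within the scatter) from compound 3 to compound 4, 9.3-fold (0.97 log units) apart, beyond the scatter of two such steps

This shows that, for these two pairs, the outcome of the change depends on the core that carries it, even though the surroundings of the place are the same, so a step measured on one core cannot be transferred to the other in this series. It does not show which feature of the two cores separates the steps or how the change would behave on any further core, and the step on the second core lies within the scatter, so it cannot be read as a real gain in tolerance.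

The compounds shown leave open whether another group at the same place between two ring nitrogen atoms, such as an amine or a methoxy group, would also differ from one core to the other. They also leave open whether the chloro step on a third core would resemble either of the two steps seen here.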